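Changing the Group on the Amide Nitrogen

This account rests on a few compounds, and the source may have more. Where it says the series, first, only, none or still open, it means among the compounds named here.

Compound 1 `Cc1ccc(-c2cc(C(=O)Nc3ccncc3)nn2-c2ccc3ccccc3n2)cc1` and compound 2 `Cc1ccc(-c2cc(C(=O)Nc3ccc(Cl)nc3Cl)nn2-c2ccc3ccccc3n2)cc1` share one core and differ only in the group on an amide-type nitrogen. In a functional assay on HCT-116 cells (Homo sapiens) for cytotoxicity, read by sulforhodamine B assay, with a stated time of 72 h (on this read-out lower numbers stand for stronger inhibition and higher numbers for weaker inhibition), compound 1 gives 8100 nM and compound 2 gives 7900 nM. The measured step is a 1.0-fold lower number from compound 1 to compound 2 (0.01 log units; within the scatter), so compound 2 stands level with compound 1 and holds no real lead.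

Compound 3 `Cc1ccc(-c2cc(C(=O)Nc3ccncc3Br)nn2-c2ccc3ccccc3n2)cc1` carries 3-bromopyridin-4-yl in place of 2,6-dichloropyridin-3-yl on an amide-type nitrogen. For the measured compounds named here, only one measured step bears on this change, the one between the groups of compound 1 and compound 2, and it stayed within the scatter. Going by the values given here, the incoming group is the pyridin-4-yl of compound 1 with a bromine added, and no compound with bromine has a measured value yet. A single step is thin evidence, so the expectation is loose: no shift beyond the scatter in this assay, in either direction. The expected step is a 1.1-fold lower number from compound 2 to compound 3 (0.02 log units; within the scatter). For compound 3 the estimated value is 7500 nM, with an expected range of 3000 nM to 20000 nM.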

Compound 3, half-maximal inhibitory concentration: 15500 nM
Estimate against measurement, compound 3: 2.1-fold (0.32 log units) below; the measured number falls inside the stated range.
By their numbers in this assay, from the lowest: compounds 2, 1 and 3 (each within the scatter of the next).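

In this assay, for the compounds shown here, moving to 3-bromopyridin-4-yl on the amide-type nitrogen gives a 2.0-fold higher number from compound 2 to compound 3 (0.29 log units; within the scatter) and is the first change here to bring in bromine, while the step of a 1.9-fold higher number from compound 1 to compound 3 (0.28 log units; within the scatter) isolates a single bromo in place of hydrogen on an aromatic carbon. Neither step leaves the scatter, so this position now holds three different pyridine groups, one bare, one with two chlorines and one with a bromine, and the change of halogen and ring attachment shows no clear effect on the number. No measurement of any property of these groups is at hand to explain this result.

The compounds shown leave open whether any group on this nitrogen can move the number beyond the scatter, for instance a plain phenyl, a pyridine carrying an amine or a methoxy, or a longer alkyl chain in place of the ring. They also leave open whether fluorine or chlorine in the place of the bromine on the pyridin-4-yl group would read the same.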